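The source may hold more compounds than are shown below. What is called first, only, known or untested is meant among the compounds shown, and "the series" means these compounds.

Measured compounds in a functional assay on MCF7 cells (Homo sapiens) for cytotoxicity, read by MTT assay, with a stated time of 48 h; on this read-out higher numbers stand for weaker inhibition and lower numbers for stronger inhibition:
Compound 1 `Cn1cc(/C=C2/C(=O)Nc3ccccc32)c2cc(Nc3nccc(-c4ccc(O)cc4)n3)ccc21` gives 39600 nM.
Compound 2 `Cn1cc(/C=C2/C(=O)Nc3ccccc32)c2cc(Nc3nccc(-c4ccc(F)cc4)n3)ccc21` gives 48100 nM.
Compound 3 `Cn1cc(/C=C2/C(=O)Nc3ccccc32)c2cc(Nc3nccc(-c4ccc(C(F)(F)F)cc4)n3)ccc21` gives 65200 nM.

Compound 3 carries the highest of the three numbers, yet neither of its comparisons leaves the scatter: a 1.4-fold higher number from compound 2 to compound 3 (0.13 log units; within the scatter) and a 1.6-fold higher number from compound 1 to compound 3 (0.22 log units; within the scatter). The remaining pair behaves the same way, with a 1.2-fold higher number from compound 1 to compound 2 (0.08 log units; within the scatter). Across hydroxy, fluoro and trifluoromethyl on the pendant aromatic ring, no step rises above the noise of the read-out.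

Compound 4 `Cn1cc(/C=C2/C(=O)Nc3ccccc32)c2cc(Nc3nccc(-c4cccnc4)n3)ccc21` has not been measured. Relative to compound 3 the change is pyridin-3-yl in place of 4-(trifluoromethyl)phenyl on an aromatic carbon. The three measured steps bear on it only loosely: each of them varies the group carried by that pendant ring while the ring itself stays the same, and each was within the scatter. The step to compound 4 exchanges the whole ring, a larger change than any seen so far, so the evidence supports an expectation of no step beyond the scatter while leaving the range wide. The expected step is therefore a 1.3-fold lower number from compound 3 to compound 4 (0.12 log units; within the scatter). Compound 4 is estimated at 50000 nM in this assay, with a range from 18000 nM to 120000 nM.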

Compound 4, half-maximal inhibitory concentration: 46600 nM
Compound 4: middle estimate off by 1.1-fold (0.03 log units), on the high side; the range from low to high includes it.
By their numbers in this assay, from the lowest: compounds 1, 4, 2 and 3 (each within the scatter of the next).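

Exchanging the whole pendant ring at this place, on the aromatic carbon next to the ring nitrogen, moves the read-out in this assay no further than exchanging a group on that ring did (a 1.4-fold lower number from compound 3 to compound 4 (0.15 log units; within the scatter); a 1.0-fold lower number from compound 2 to compound 4 (0.01 log units; within the scatter); a 1.2-fold higher number from compound 1 to compound 4 (0.07 log units; within the scatter)). The series now covers a ring of carbon only and pyridin-3-yl, which brings a ring nitrogen and a hydrogen-bond acceptor and has fewer heavy atoms than 4-(trifluoromethyl)phenyl, and all four compounds remain within the scatter of one another, with none going against this flat picture and no order among them. Nothing at hand gives a reason for this flat response at the position.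

Going by these compounds, it remains open whether any group at this place can produce a step beyond the scatter, for example a carboxylic acid or an aminomethyl group on the pendant ring, or a morpholine in place of that ring. The compounds shown also leave open whether the same flat response would hold with a different group on the shared core, since every change so far falls at this one position.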